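Aryl swap on the cinnamamide chain of compound 3

A few compounds are considered here, and "the series" means these few. Any claim that something is new, unique, unknown or untested is made for them only; others in the source may bear on it.

Measured so far:
compound 1 `COc1ccc(C(=O)c2cc(OC)c(OC)c(OC)c2)cc1NC(=O)/C=C/c1ccc(OC)c(OC)c1` — 10200 nM
compound 2 `COc1ccc(C(=O)c2cc(OC)c(OC)c(OC)c2)cc1NC(=O)/C=C/c1ccc(C(F)(F)F)cc1` — 4300 nM
compound 3 `COc1ccc(/C=C/C(=O)Nc2cc(C(=O)c3cc(OC)c(OC)c(OC)c3)cc(OC)c2OC)cc1OC` — 7800 nM

All three numbers come from a functional assay on DU-145 cells (Homo sapiens) for cytotoxicity, read by MTT assay, with a stated time of 72 h; a higher number here means a weaker inhibitor, a lower number a stronger inhibitor. Compound 3 stands second highest of the three. Compound 1 is its nearest neighbour, and the gap is within the scatter: a 1.3-fold lower number from compound 1 to compound 3 (0.12 log units; within the scatter). Compound 2 is the furthest, yet the gap between compound 3 and compound 2 is also within the scatter, so no order among the three can be claimed.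

Compound 4 `COc1cc(C(=O)c2cc(OC)c(OC)c(OC)c2)cc(NC(=O)/C=C/c2cc(F)c(F)c(F)c2)c1OC` is not yet measured. It differs from compound 3 in one place: 3,4,5-trifluorophenyl in place of 3,4-dimethoxyphenyl on a double-bonded chain carbon bound to a double-bonded chain carbon. Within the data shown here, the only measured step that bears on this is the one from compound 1 to compound 2, where the same 3,4-dimethoxyphenyl gave way to a fluorine-bearing aryl on the same chain carbon: a 2.4-fold lower number from compound 1 to compound 2 (0.38 log units; beyond the scatter). That step was modest but beyond the scatter. Among the measured compounds shown here, a step of similar size and direction is therefore expected for compound 4 in this assay, as a 2.0-fold lower number from compound 3 to compound 4 (0.29 log units; within the scatter), with a wide range because only one such step supports it.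

Compound 4 is accordingly estimated at 4000 nM in this assay, between 1500 nM and 10000 nM.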

Compound 4, half-maximal inhibitory concentration: 7900 nM
Estimate against measurement, compound 4: 2.0-fold (0.30 log units) below; measured number inside the range.
By their numbers in this assay, from the lowest: compounds 2, 3, 4 and 1 (each within the scatter of the next, the first and the last beyond it).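

In this assay, 3,4,5-trifluorophenyl in place of 3,4-dimethoxyphenyl on a double-bonded chain carbon bound to a double-bonded chain carbon gives no readable change on the core of compound 3 (a 1.0-fold higher number from compound 3 to compound 4 (0.01 log units; within the scatter)). The earlier step at this position (a 2.4-fold lower number from compound 1 to compound 2 (0.38 log units; beyond the scatter)) therefore does not extend to every fluorine-bearing aryl group, since the position now holds one such group with a step beyond the scatter and another with a step within it, although the two steps were taken on different cores and with different aryl groups. Nothing shown accounts for the contrast between these two steps.

From the compounds shown here alone, it remains open whether 4-(trifluoromethyl)phenyl would give a similar step on the core of compound 3, which would separate the choice of aryl group from the choice of core. Also open, going by these compounds, is how the read-out in this assay would respond to an amine or a carboxylic acid on the aryl ring at this position, or to a longer chain carrying that ring.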